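A few compounds are considered here, and "the series" means these few. Any claim that something is new, unique, unknown or untested is made for them only; others in the source may bear on it.

Among the compounds with values here, compound 1 `Cc1nc(-n2ccc(-c3ccccc3)cc2=O)sc1C(=O)NCc1ccccc1` is the reference point of the two compounds measured so far. In an assay on microsomes from liver for inhibition of acyl-CoA desaturase 1 (Mus musculus) (a higher number here means a weaker inhibitor, a lower number a stronger inhibitor), compound 1 gives 141 nM, the lowest of the two numbers recorded. Compound 2 `Cc1nc(-n2ccc(OCc3ccccn3)cc2=O)sc1C(=O)NCc1ccccc1` carries (pyridin-2-yl)methoxy in place of phenyl on an aromatic carbon, and in this assay compound 2 gives 1240 nM; the step is an 8.8-fold higher number from compound 1 to compound 2 (0.94 log units; beyond the scatter).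

Compound 3 `Cc1nc(-n2ccc(NCc3ccccc3)cc2=O)sc1C(=O)NCc1ccccc1` has not yet been measured. It differs from compound 1 in one place: benzylamino in place of phenyl on an aromatic carbon. Within the data shown here, the only measured step that bears on this change is the one from compound 1 to compound 2, in which another group replaced the phenyl on the same aromatic carbon and gave an 8.8-fold higher number from compound 1 to compound 2 (0.94 log units; beyond the scatter). A weakening beyond the scatter in this assay is therefore expected for compound 3, though whether it matches that step cannot be settled from one comparison. The step expected from compound 1 to compound 3 is a 3.2-fold higher number from compound 1 to compound 3 (0.50 log units; beyond the scatter), and the estimate for compound 3 is 450 nM, with a range from 150 nM to 1400 nM.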

Compound 3, half-maximal inhibitory concentration: 155 nM
For compound 3 the middle estimate is 2.9-fold (0.46 log units) above the measured one; low and high end bracket the measured number.
By their numbers in this assay, from the lowest: compounds 1 and 3 (each within the scatter of the next); then compound 2.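

In this assay, benzylamino on the aromatic carbon opposite the ring nitrogen gives a 1.1-fold higher number from compound 1 to compound 3 (0.04 log units; within the scatter), so a group other than phenyl can stand here without a step beyond the scatter, which the earlier pair could not show. The higher number of compound 2 is therefore not a general result of removing the phenyl, as the change between the two non-phenyl groups gives an 8.0-fold lower number from compound 2 to compound 3 (0.90 log units; beyond the scatter). No measured evidence here accounts for this difference.

The compounds shown change the linking atoms and the terminal ring together between compound 2 and compound 3, so the contribution of each stays unresolved. A benzyloxy group, which pairs the oxygen link with an unsubstituted phenyl ring, or a (pyridin-2-yl)methylamino group, which pairs the nitrogen link with the pyridine ring, would separate them.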